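Chain lengthening between the two aryl ethers of compound 1

The source may hold more compounds than are shown below. What is called first, only, known or untested is meant among the compounds shown, and "the series" means these compounds.

Measured so far:
- compound 1, `CC(C)NC(=N)c1ccc2cc(-c3cccc(OCCCCOc4ccccc4)c3)oc2c1`: 46500 nM
- compound 2, `c1ccc(OCCCCOc2cccc(-c3cc4ccc(C5=NCCN5)cc4o3)c2)cc1`: 5800 nM

In an ADME assay on L6 cells (Rattus norvegicus) for cytotoxicity, read by resazurin assay, with a stated time of 70 h (on this read-out higher numbers stand for weaker inhibition and lower numbers for stronger inhibition), compound 1 gives 46500 nM, the higher of the two numbers. For the measured compounds named here, compound 2 gives 5800 nM, and the one measured step, an 8.0-fold lower number from compound 1 to compound 2 (0.90 log units; beyond the scatter), comes from a change at the amidine end of the shared core.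

Compound 3, `CC(C)NC(=N)c1ccc2cc(-c3cccc(OCCCCCCOc4ccccc4)c3)oc2c1`, differs from compound 1 elsewhere: 2-phenoxyethyl in place of phenoxy on a saturated chain carbon, four bonds along the chain from an oxygen on an aromatic ring. Going by the values given here, this change touches neither the amidine nor the core, and no measured pair shows what lengthening the linker between the two aryl ethers does in this assay. Among the compounds with values here, the step from compound 1 to compound 2 therefore does not bear on it, and nothing among the measured compounds points in either direction.

Within the data shown here, with no comparable step to lean on, compound 3 is expected to stay close to compound 1, with no change at the digits printed from compound 1 to compound 3 (within the scatter) as the expected step, but with a wide range to allow for the unknown. The estimate for compound 3 is 46500 nM, spanning 15000 nM to 140000 nM.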

Compound 3, half-maximal inhibitory concentration: 10100 nM
Beside the measured number, compound 3's estimate is 4.6-fold (0.66 log units) above it; measured number below the stated range.
By their numbers in this assay, from the lowest: compounds 2 and 3 (each within the scatter of the next); then compound 1.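

In this assay, swapping phenoxy for 2-phenoxyethyl on the chain gives a 4.6-fold lower number from compound 1 to compound 3 (0.66 log units; beyond the scatter). The earlier compounds shown here showed a change in this number only at the amidine end of the shared core, whereas this step, which lies beyond the scatter, shows that the number also responds to a change in the chain while the amidine and the core stay the same. The entering and leaving groups have the same aromatic ring and lack of net charge, but nothing available explains why the number falls.

For the compounds shown here, with only this one step at this position, it remains open whether a longer chain, such as 4-phenoxybutyl in place of phenoxy, would lower the number further, leave it unchanged or raise it. Also open, from the compounds shown here alone, are the effect of an amine or a carboxylic acid on the terminal phenyl ring, and whether 2-phenoxyethyl would act in the same way on the core of compound 2, which carries the five-membered non-aromatic ring.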